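Replacing a Chain End with a Hydroxy Group

The compounds below may be only part of what the source reports. "The series", "measured", "known", "first", "only" and "open" are said of these compounds alone.

Measured compounds:
- Compound 1, `Cn1cncc1C(OCc1ccc(C#N)cc1C#Cc1ccccn1)c1ccc(C#N)cc1`: in a functional assay on NIH3T3 cells (Mus musculus) (on this read-out higher numbers stand for an effect only at larger amounts of compound and lower numbers for an effect already at smaller amounts), compound 1 gives > 0.1 nM, which is a limit of the assay and not a number.
- Compound 2, `Cn1cncc1C(OCc1ccc(C#N)cc1C#Cc1ccccc1)c1ccc(C#N)cc1`: in this assay compound 2 gives 0.1 nM.
- Compound 3, `CCCCCCC#Cc1cc(C#N)ccc1COC(c1ccc(C#N)cc1)c1cncn1C`: in this assay compound 3 gives > 0.1 nM, again a limit and not a number.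

Compound 3 therefore stands at the edge of what this assay can report, and its position relative to the other two is not readable from the values shown. Among the measured compounds shown here, the step of a number no lower from compound 2 to compound 3 (the limit leaves the size open) tells only that the number did not fall; the step that the two limits leave unreadable from compound 1 to compound 3 tells nothing about size; both rest on (the limit of > 0.1 nM in this assay, at which 2 of the 3 values shown sit). In compound 3 a hexyl group sits on a triple-bonded carbon, and in compound 1 a pyridin-2-yl, in compound 2 a phenyl.

Compound 4, `Cn1cncc1C(OCc1ccc(C#N)cc1C#CCCCCO)c1ccc(C#N)cc1`, changes the hexyl chain of compound 3: hydroxy in place of ethyl on a saturated chain carbon, four bonds along the chain from a triple-bonded carbon. For the measured compounds named here, no measured pair shows this kind of change, so no step can be borrowed directly. With compound 3 sitting at the limit, the size of a step that the limit leaves unreadable from compound 3 to compound 4 is an estimate with little anchoring. Compound 4 is expected to give about 0.3 nM in this assay, within 0.1 nM to 3 nM.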

Compound 4, half-maximal effective concentration: 20.9 nM
Compound 4: middle estimate off by 70-fold (1.84 log units), on the low side; the whole stated range lies below it.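

Among the compounds shown here, compound 4 brings the first step at this position with a readable size: in this assay there is a 210-fold higher number from compound 2 to compound 4 (2.32 log units; beyond the scatter), so with a 4-hydroxybutyl group on the triple-bonded carbon, an effect takes far more compound than with the phenyl group. The closest relative of compound 4 is compound 3. Compound 3 gives > 0.1 nM, which is a limit of the assay and not a number. The steps from compound 3 and from compound 1 to compound 4 cannot be read, so the swap of ethyl for hydroxy has no size of its own, for this reason: the limit of > 0.1 nM in this assay, at which 2 of the 4 values shown sit.

As far as these compounds go, it remains open how much of the large step from the phenyl compound comes from the hydroxy group and how much from having a saturated chain instead of a ring on the triple-bonded carbon. Also open, from the compounds shown here alone, is whether an amine or a carboxylic acid in place of the hydroxy, or a longer chain carrying the hydroxy, would give a number close to that of compound 4.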